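Three sulfonamides at the assay limit, a fourth awaited

A few compounds are considered here, and "the series" means these few. Any claim that something is new, unique, unknown or untested is made for them only; others in the source may bear on it.

Compound 1 `O=S(=O)(Nc1ccc(-c2nc3ccccc3o2)cc1)c1ccccc1Cl`: > 63000 nM
Compound 2 `COc1cccc(S(=O)(=O)Nc2ccc3oc(-c4ccccc4)nc3c2)c1`: > 63000 nM
Compound 3 `O=S(=O)(Nc1ccc2oc(-c3ccccc3)nc2c1)c1ccc(Cl)c(Cl)c1`: > 63000 nM

In an assay on isolated protein for inhibition of malate dehydrogenase, mitochondrial (Sus scrofa), with stated times of 45 min and 30 min (a higher number here means a weaker inhibitor, a lower number a stronger inhibitor), compound 1 gives > 63000 nM, which is a limit of the assay and not a number. Compound 2 and compound 3 likewise reach only the limit, so the step that the two limits leave unreadable from compound 2 to compound 3 cannot be read. In short, (the limit of > 63000 nM in this assay, at which 3 of the 3 values shown sit). Compound 4 `COc1ccc(Cl)cc1S(=O)(=O)Nc1ccc(-c2nc3ccccc3o2)cc1` differs from compound 1 by 5-chloro-2-methoxyphenyl in place of 2-chlorophenyl on a sulfonyl sulfur. No measured step touches this change, and the one step shown is unreadable, so there is nothing to set an expected size or direction. Compound 4 is therefore expected to sit at the limit again, with a step that the limit leaves unreadable from compound 1 to compound 4 as the expected step. The estimate for compound 4 is 100000 nM, between 40000 nM and 300000 nM.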

Compound 4, half-maximal inhibitory concentration: > 63000 nM
Compound 4: no number, only a limit (the forecaster's own chance of this, stated with the estimate: 85%); the middle value is on the limit's open side.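

Going by these compounds alone, compound 1 and compound 4 both reach only a limit of the assay, so the change between them cannot be read, and no new step emerges. What remains open is which change, if any, would bring a compound into measurable range in this assay: the limit of > 63000 nM in this assay, at which 4 of the 4 values shown sit.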